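The compounds below may be only part of what the source reports. "The series", "measured", "known", "first", "only" and "open" are said of these compounds alone.

Compound 2 `C=C1CC[C@@H]2[C@](C)(CNCc3ccc(Cl)cc3)[C@H](O)CC[C@@]2(C)[C@@H]1/C=C/C1=CCOC1=O` stands lowest of the two numbers shown in a functional assay on BMMC cells (Mus musculus, strain C57BL/6) for inhibition, with stated times of 5 days and 48 h (a lower number here means a stronger inhibitor, a higher number a weaker inhibitor), where compound 2 gives 420 nM; its nearest neighbour is compound 1 `C=C1CC[C@@H]2[C@](C)(CNCc3ccc(OC)c(OC)c3)[C@H](O)CC[C@@]2(C)[C@@H]1/C=C/C1=CCOC1=O`, which gives 3740 nM. Among the compounds with values here, the only measured step, an 8.9-fold lower number from compound 1 to compound 2 (0.95 log units; beyond the scatter), came from putting 4-chlorophenyl in place of 3,4-dimethoxyphenyl. Compound 3 `C=C1CC[C@@H]2[C@](C)(CNCc3ccc(Br)cc3)[C@H](O)CC[C@@]2(C)[C@@H]1/C=C/C1=CCOC1=O` differs from compound 2 by bromo in place of chloro on an aromatic carbon. Within the data shown here, no measured step bears directly on one halogen replacing another, and this change is far smaller than the one already seen, so the expected step is a 1.1-fold lower number from compound 2 to compound 3 (0.02 log units; within the scatter), none beyond the scatter. Compound 3 is therefore estimated at 400 nM, between 180 nM and 900 nM.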

Compound 3, half-maximal inhibitory concentration: 430 nM
Compound 3: the middle estimate sits 1.1-fold (0.03 log units) below what was measured; low and high end bracket the measured number.
By their numbers in this assay, from the lowest: compounds 2 and 3 (each within the scatter of the next); then compound 1.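

In this assay, bromo in place of chloro on this aromatic carbon, para to a large group, gives (a 1.0-fold higher number from compound 2 to compound 3 (0.01 log units; within the scatter)), so the two halogens cannot be told apart here. The step from the 3,4-dimethoxyphenyl compound (an 8.7-fold lower number from compound 1 to compound 3 (0.94 log units; beyond the scatter)) nearly matches the one seen with chloro, so that difference now holds for two halogens. No evidence is available on why the two halogens read alike.

The compounds shown leave open whether fluoro, iodo or methyl here would read the same. They also leave open whether a single methoxy group would read like compound 1 or like compound 2.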